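A few compounds are considered here, and "the series" means these few. Any claim that something is new, unique, unknown or untested is made for them only; others in the source may bear on it.

In a functional assay on Caco-2 cells (Homo sapiens), read by MTT assay, with a stated time of 48 h; a lower number here means a stronger inhibitor, a higher number a weaker inhibitor:
- compound 1 `CCN(CC)CCNC(=O)c1ccc(C(CC)(CC)c2ccc(OCC(=O)C(C)(C)C)c(C)c2)n1CC`: 1600 nM
- compound 2 `CCN(CC)CCCNC(=O)c1ccc(C(CC)(CC)c2ccc(OCC(=O)C(C)(C)C)c(C)c2)n1CC`: 1000 nM
- compound 3 `CCOC(=O)CN(C)C(=O)c1ccc(C(CC)(CC)c2ccc(OCC(O)C(C)(C)C)c(C)c2)n1CC`: 12200 nM

Compound 3 has the highest of the three numbers in this assay, and its gaps to compound 1 and compound 2 both lie beyond the scatter. The step to compound 4 `CCN(CC)CCNC(=O)c1ccc(C(CC)(CC)c2ccc(OCC(O)C(C)(C)C)c(C)c2)n1CC` is (2-(diethylamino)ethyl)amino in place of ((ethoxycarbonyl)methyl)(methyl)amino on a carbonyl carbon.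

Within the data shown here, no measured step makes this exact exchange. Among the measured compounds shown here, the one step available, a 1.6-fold lower number from compound 1 to compound 2 (0.20 log units; within the scatter), concerns only the chain carrying the diethylamino group and gives no guide to the size of the exchange. The nearest evidence is compound 1, which carries the entering group and gives 1600 nM, although it also differs from compound 4 elsewhere. A lower number than that of compound 3 is therefore expected, beyond the scatter, but the size remains uncertain. The expected change is a 5.5-fold lower number from compound 3 to compound 4 (0.74 log units; beyond the scatter). For compound 4 the estimate is 2200 nM, with an expected range of 900 nM to 6000 nM.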

Compound 4, half-maximal inhibitory concentration: 2310 nM
Estimate against measurement, compound 4: 1.1-fold (0.02 log units) below, within the range that was stated.
By their numbers in this assay, from the lowest: compounds 2, 1 and 4 (each within the scatter of the next, the first and the last beyond it); then compound 3.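

In this assay, among these compounds, placing (2-(diethylamino)ethyl)amino in place of ((ethoxycarbonyl)methyl)(methyl)amino on a carbonyl carbon gives a 5.3-fold lower number from compound 3 to compound 4 (0.72 log units; beyond the scatter) and so provides the first measured exchange at this place, with a change beyond the scatter. With (2-(diethylamino)ethyl)amino held constant, 1-hydroxy-2,2-dimethylpropyl in place of (tert-butyl)carbonyl gives a 1.4-fold higher number from compound 1 to compound 4 (0.16 log units; within the scatter) and leaves the two compounds unseparated. Among the compounds shown here, the first exchange therefore separates compounds at the carbonyl carbon, whereas this second change does not separate them at its own place.

Because the whole group changes at once, the compounds shown leave open which part of it goes with the step, and what a carboxylic acid in place of the ethyl ester or a morpholine in place of the diethylamino group would give. No measurement at hand explains either step.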